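The source may report more compounds than this note shows. Statements on the series, on what has been measured and on what is new or still open speak of the compounds shown alone.

Going by the values given here, the three compounds measured so far share one core and differ only in the aromatic ring attached to it. Compound 1 `CCCS(=O)(=O)Nc1ccc(F)c(C(=O)c2n[nH]c3ncc(-c4ccccc4C)cc23)c1F` carries a 2-methylphenyl group and gives 7% in an assay for binding affinity to dual specificity mitogen-activated protein kinase kinase 4 (Homo sapiens), read by KINOMEscan, tested at 100 nM; a lower number here means a stronger effect, a higher number a weaker effect of the compound at the concentration tested. Compound 2 `CCCS(=O)(=O)Nc1ccc(F)c(C(=O)c2n[nH]c3ncc(-c4ccccc4OC)cc23)c1F` carries a 2-methoxyphenyl group and gives 1.9%. Compound 3 `CCCS(=O)(=O)Nc1ccc(F)c(C(=O)c2n[nH]c3ncc(-c4ccc(O)cc4)cc23)c1F` carries a 4-hydroxyphenyl group and gives 0.75%, the lowest of the three numbers, though each of its distances to the others lies within the scatter: a number 1.2 percentage points lower from compound 2 to compound 3 (within the scatter) and a number 6.3 percentage points lower from compound 1 to compound 3 (within the scatter). Compound 4 `CCCS(=O)(=O)Nc1ccc(F)c(C(=O)c2n[nH]c3ncc(-c4ccc(C)c(C)c4)cc23)c1F` has not yet been measured and differs from compound 3 in one place: 3,4-dimethylphenyl in place of 4-hydroxyphenyl on an aromatic carbon. Among the compounds with values here, the steps that bear on this change are the three in which this same attached ring was exchanged, a number 5.1 percentage points lower from compound 1 to compound 2 (within the scatter), a number 6.3 percentage points lower from compound 1 to compound 3 (within the scatter) and a number 1.2 percentage points lower from compound 2 to compound 3 (within the scatter), and none of them moved the read-out beyond the scatter. Another exchange of this ring is therefore expected to give no step beyond the scatter, with the number staying low. Compound 4 is estimated to give 3% in this assay, within a range from 0.4% to 12%, which corresponds to an expected step of a number 2.3 percentage points higher from compound 3 to compound 4 (within the scatter).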

Compound 4, a percentage reported as activity, at one concentration (the size of the read-out at that concentration, not a potency): 20%
For compound 4 the middle estimate is 17 percentage points below the measured one, outside the stated range (above it).
By their numbers in this assay, from the lowest: compounds 3, 2 and 1 (each within the scatter of the next); then compound 4.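

Exchanging the ring at this position can change the read-out after all: in this assay the move to 3,4-dimethylphenyl gives a number 19.3 percentage points higher from compound 3 to compound 4 (beyond the scatter) and a number 18.1 percentage points higher from compound 2 to compound 4 (beyond the scatter) and a number 13 percentage points higher from compound 1 to compound 4 (beyond the scatter). The rings of compound 1 and compound 4 both lack oxygen and a hydrogen-bond donor, yet their step lies beyond the scatter, so the absence of these features does not by itself set compound 4 apart. Nothing available here explains why this ring behaves differently.

The compounds shown do not separate the effect of having two methyl groups from the effect of where they sit on the ring. They also leave open how an amine, a carboxylic acid or a longer chain such as propyl on this ring would read.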